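The source may hold more compounds than are shown below. What is called first, only, known or untested is meant among the compounds shown, and "the series" means these compounds.

Measured compounds:
Compound 1 `COC(=O)c1cc(-c2cccc(NC(=O)c3ccc(/C=C/C(=O)c4cccc(F)c4)cc3)c2)on1` — in an ADME assay on Vero cells (Chlorocebus sabaeus) for cytotoxicity, read by MTT assay, with a stated time of 72 h (on this read-out higher numbers stand for lower toxicity in this test and lower numbers for higher toxicity in this test), compound 1 gives > 40 ug/mL, which is a limit rather than a number.
Compound 2 `COC(=O)c1cc(-c2cccc(NC(=O)c3ccc(/C=C/C(=O)c4ccc(C)cc4)cc3)c2)on1` — in this assay compound 2 gives > 80 ug/mL, which is also a limit rather than a number.

Among the compounds with values here, compound 2 stands only at a limit in this assay; the one further value shown, that of compound 1, is likewise a limit. Within the data shown here, the single measured step, a step that the two limits leave unreadable from compound 1 to compound 2, is accordingly of unreadable size. Compound 3 `COC(=O)c1cc(-c2cccc(NC(=O)c3ccc(/C=C/C(=O)c4cccc(Br)c4)cc3)c2)on1` has not yet been measured. It differs from compound 2 by 3-bromophenyl in place of 4-methylphenyl on a carbonyl carbon. Among the measured compounds shown here, the only measured step bearing on this position is the unreadable one just named, so no measured size can be carried over. What the numbers do show is that both measured compounds sit at limits, namely the limit of > 40 ug/mL in this assay, at which 1 of the 2 values shown sits, and (the limit of > 80 ug/mL in this assay, at which 1 of the 2 values shown sits). On that basis compound 3 is expected to show no step beyond the scatter, an at least 1.3-fold lower number from compound 2 to compound 3 (0.12 log units; that floor lies within the scatter), and most likely to be reported at a limit again. Compound 3 is estimated at 60 ug/mL, with a range from 20 ug/mL to 150 ug/mL.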

Compound 3, half-maximal cytotoxic concentration: > 100 ug/mL
Compound 3 gave a limit, no number (the forecaster's own chance of this, stated with the estimate: 70%); middle value at least 1.6-fold (0.22 log units) from the limit.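

In this assay compound 3 gives > 100 ug/mL, which is a limit and not a number. With compound 1 and compound 2 also standing at limits, the steps linking these compounds cannot be read. The compounds shown leave open where any of the three truly lies, and whether changing the group on the carbonyl carbon alters the read-out at all.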